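Swapping 3-methylphenyl for benzyl on a shared scaffold

The compounds below may be only part of what the source reports. "The series", "measured", "known", "first", "only" and "open" are said of these compounds alone.

Measured so far in a functional assay on a cell-free system (plasma, Homo sapiens), with a stated time of 3 min (a higher number here means a weaker inhibitor, a lower number a stronger inhibitor), for three compounds:
Compound 1 `O=C(NCc1cc(Cl)ccc1-n1cnnn1)[C@@H]1C[C@@H]2C[C@@H]2N1C(=O)[C@H](O)c1cccc(Cl)c1` gives 1000 nM
Compound 2 `Cc1cccc([C@@H](O)C(=O)N2N=CC[C@H]2C(=O)NCc2cc(Cl)ccc2-n2cnnn2)c1` gives 830 nM
Compound 3 `CC(C)(C)[C@@H](O)C(=O)N1C[C@@H]2C[C@@H]2[C@H]1C(=O)NCc1cc(Cl)ccc1-n1cnnn1` gives 570 nM

The value of compound 2 falls among the other two numbers and lies within the usual scatter of both, so the three cannot be put in a firm order. Compound 4 `O=C(NCc1cc(Cl)ccc1-n1cnnn1)[C@@H]1CC=NN1C(=O)[C@H](O)Cc1ccccc1` has no value yet. Its structure differs from that of compound 2 in one place (benzyl in place of 3-methylphenyl on a saturated chain carbon bound to a carbonyl carbon and an oxygen on a saturated carbon), with benzyl in place of 3-methylphenyl on a saturated chain carbon bound to a carbonyl carbon and an oxygen on a saturated carbon.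

For the measured compounds named here, no two measured compounds differ in just one place, so the data give no direct guide to the size of this change. The three measured compounds differ from one another in several places, yet their values stay close, which gives no sign of a large jump. A small move towards a higher number, meaning a somewhat weaker inhibitor, is therefore expected, probably not beyond the scatter. The estimate is a 1.7-fold higher number from compound 2 to compound 4 (0.23 log units; within the scatter) (an expected change, not a measured one). In this assay compound 4 is expected at about 1400 nM (estimated range 350 nM to 5000 nM).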

Compound 4, half-maximal inhibitory concentration: 1400 nM
Beside the measured number, compound 4's estimate shows no gap at the digits printed; measured number inside the range.
By their numbers in this assay, from the lowest: compounds 3, 2, 1 and 4 (each within the scatter of the next, the first and the last beyond it).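

For the compounds shown here, this is the first pair here that differs in one place only, so it gives the first direct reading of a change at this position: in this assay, benzyl in place of 3-methylphenyl on a saturated chain carbon bound to a carbonyl carbon and an oxygen on a saturated carbon gives a 1.7-fold higher number from compound 2 to compound 4 (0.23 log units; within the scatter) and so does not separate the two compounds. The two groups have the same heavy-atom count and the same six-membered aromatic ring of carbon only, and on this shared core the exchange leaves no readable difference between them. Nothing measured here bears on why the two groups read alike.

The compounds shown leave open whether a different kind of group at this place, such as an amine, a carboxylic acid or a longer chain ending in a phenyl ring, would give a number clearly apart from these. They also leave open whether the same exchange of 3-methylphenyl for benzyl would read alike on the core of compound 1 or the core of compound 3.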